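A few compounds are considered here, and "the series" means these few. Any claim that something is new, unique, unknown or untested is made for them only; others in the source may bear on it.

Compound 1 `COc1ccccc1-c1ncnn1-c1cc(OC)c(OC)c(OC)c1`: in a functional assay on HeLa cells (Homo sapiens) for antiproliferative activity, read by MTT assay, with a stated time of 72 h (a lower number here means a stronger inhibitor, a higher number a weaker inhibitor), compound 1 gives > 10000 nM, a limit of the assay.
Compound 2 `COc1cc(-n2ncnc2-c2ccc(Cl)c(Cl)c2)cc(OC)c1OC`: in this assay compound 2 gives > 10000 nM, likewise a limit.

Compound 2 thus stands at the limit of > 10000 nM in this assay, at which 2 of the 2 values shown sit. The one step shown, a step that the two limits leave unreadable from compound 1 to compound 2, cannot be read from two limits. Compound 3 `COc1cc(-n2ncnc2-c2ccc(SC)cc2)cc(OC)c1OC` differs from compound 2 by 4-(methylsulfanyl)phenyl in place of 3,4-dichlorophenyl on an aromatic carbon. Among the measured compounds shown here, no measured step bears on this change, and no value beneath the limit exists to scale it. Compound 3 is expected to give 10000 nM in this assay, within 3000 nM to 30000 nM. The expected step of a number no higher from compound 2 to compound 3 (the limit leaves the size open) is therefore none beyond the scatter.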

Compound 3, half-maximal inhibitory concentration: 150 nM
The estimate for compound 3 lay 67-fold (1.82 log units) above the measured number; the whole stated range lies above it.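

The change at this aromatic carbon of the five-membered ring gives the first readable activity: 4-(methylsulfanyl)phenyl in place of 3,4-dichlorophenyl gives an at least 66-fold lower number from compound 2 to compound 3 (1.82 log units; beyond the scatter), and in place of 2-methoxyphenyl gives an at least 66-fold lower number from compound 1 to compound 3 (1.82 log units; beyond the scatter). The position therefore admits a strong inhibitor, and only compound 3 lies beneath the limit, with the other two sitting at it: the limit of > 10000 nM in this assay, at which 2 of the 3 values shown sit.

Still open, on these data alone, is which feature of the entering group matters, since the sulfur, its methyl and its place on the phenyl ring all change together. As far as these compounds go, whether 4-methoxyphenyl, 4-aminophenyl or 4-(ethylsulfanyl)phenyl would keep this activity also remains unknown.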